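Swapping Hydroxy for Dimethylamino on the Shared Core

The source may hold more compounds than are shown below. What is called first, only, known or untested is meant among the compounds shown, and "the series" means these compounds.

Of the compounds shown here, three built on the same core have been tested in a functional assay on KB cells (Homo sapiens) for cytotoxicity, read by MTT assay, with a stated time of 72 h; a higher number here means that more compound is needed for the effect, a lower number that less compound is needed. Compound 1 `COc1ccc(/C=C2\C(=O)N(c3c(Cl)cccc3Cl)c3ccccc32)cc1OC` gives 10 ug/mL. Compound 3 `O=C1/C(=C\c2cccc(Oc3ccccc3)c2)c2ccccc2N1c1c(Cl)cccc1Cl` gives 5 ug/mL. Compound 2 `O=C1/C(=C\c2ccc(O)cc2)c2ccccc2N1c1c(Cl)cccc1Cl` gives 2 ug/mL, the lowest of the three numbers; its gap to compound 3 and its larger gap to compound 1 both lie beyond the usual scatter, so on these numbers compound 2 needs the least material for the effect.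

Compound 4 `CN(C)c1ccc(/C=C2\C(=O)N(c3c(Cl)cccc3Cl)c3ccccc32)cc1` differs from compound 2 in one place: dimethylamino in place of hydroxy on an aromatic carbon. Among the compounds with values here, no pair of measured compounds differs only in this way, so there is no direct precedent. Since every hydroxy-free variant so far, compound 1 and compound 3, needed more material than compound 2, a small rise is expected for compound 4, and in this assay the step of a 1.8-fold higher number from compound 2 to compound 4 (0.24 log units; within the scatter) is estimated to stay close to the scatter. Compound 4 is therefore expected to give about 3.5 ug/mL, within a range from 1 ug/mL to 12 ug/mL.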

Compound 4, concentration for half-maximal effect: 15 ug/mL
Compound 4: the middle estimate sits 4.3-fold (0.63 log units) below what was measured; measured number above the stated range.
By their numbers in this assay, from the lowest: compound 2; then compounds 3, 1 and 4 (each within the scatter of the next, the first and the last beyond it).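

Putting dimethylamino in place of hydroxy on this aromatic carbon gives a 7.5-fold higher number from compound 2 to compound 4 (0.88 log units; beyond the scatter) in this assay, a step beyond the scatter. Within the data shown here, compound 1 and compound 3 each differ from compound 2 in more than one place, so this is the first single change that can be read at this position, and it shows that the group held here matters for the number. The exchange removes the hydrogen-bond donor and raises the group from one heavy atom to three, but no measurement shown explains the rise.

The two differences remain tied together in this pair, so the loss of the donor cannot be separated from the added size. A plain amino group at the same place would keep a hydrogen on nitrogen and would help to pull those two differences apart.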